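Swapping Phenyl for a Hydroxybutynyl Chain

The source may report more compounds than this note shows. Statements on the series, on what has been measured and on what is new or still open speak of the compounds shown alone.

Compound 1, `CC1=C/C(=C\c2cccs2)C(=O)C(C)(O)C12CC2`: in a functional assay on SW480 cells (Homo sapiens) for antiproliferative activity (on this read-out higher numbers stand for weaker inhibition and lower numbers for stronger inhibition), compound 1 reaches only the assay limit of > 10000 nM.
Compound 2, `CC1=C/C(=C\c2ccccc2)C(=O)C(C)(O)C12CC2`: in this assay compound 2 gives 2500 nM.

Among the compounds with values here, compound 2 is the only compound with a number here; the other value is a limit. Within the data shown here, the one measured step, an at least 4.0-fold lower number from compound 1 to compound 2 (0.60 log units; beyond the scatter), shows that the group on the double-bonded chain carbon matters at least modestly, though the start is an assay limit (the limit of > 10000 nM in this assay, at which 1 of the 2 values shown sits).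

Compound 3, `CC1=C/C(=C\C#CCCO)C(=O)C(C)(O)C12CC2`, carries the change (4-hydroxybut-1-yn-1-yl in place of phenyl on a double-bonded chain carbon bound to a double-bonded ring carbon). Among the measured compounds shown here, no measured step tests an aryl-to-alkynyl exchange, so only the direction that group changes can count for much. Because the measured step of an at least 4.0-fold lower number from compound 1 to compound 2 (0.60 log units; beyond the scatter) moved with a small aryl swap, a larger change to a chain with a hydroxyl is expected to weaken inhibition, with a 2.4-fold higher number from compound 2 to compound 3 (0.38 log units; beyond the scatter). For compound 3 the estimated value in this assay is 6000 nM, within 1500 nM to 20000 nM.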

Compound 3, half-maximal inhibitory concentration: 4000 nM
Estimate against measurement, compound 3: 1.5-fold (0.18 log units) above; the measured number falls inside the stated range.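

In this assay, 4-hydroxybut-1-yn-1-yl in place of phenyl gives a 1.6-fold higher number from compound 2 to compound 3 (0.20 log units; within the scatter), so the two compounds cannot be told apart on this read-out. This position on the double-bonded chain carbon therefore does not need an aromatic ring to hold this level of activity: a chain with no ring, a triple bond and a hydroxyl serves as well as phenyl here. The same chain in place of thiophen-2-yl gives an at least 2.5-fold lower number from compound 1 to compound 3 (0.39 log units; beyond the scatter), which leaves thiophen-2-yl as the group that stands apart from the other two, though compound 1 is read only from an assay limit: the limit of > 10000 nM in this assay, at which 1 of the 3 values shown sits.

The compounds shown do not separate the part played by the hydroxyl from that of the triple bond. A plain but-1-yn-1-yl chain, or a longer chain ending in an amine, would be needed to tell them apart.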